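The compounds below may be only part of what the source reports. "The series", "measured", "known", "first", "only" and "open" are said of these compounds alone.

Measured in a functional assay on cells for antagonist activity at C-X-C chemokine receptor type 4 (Homo sapiens), read by fluorescence and calcium flux, with stated times of 25 min and 90 s; a higher number here means a weaker inhibitor, a lower number a stronger inhibitor:
Compound 1, `c1ccc2c(c1)CN[C@@H](CN(CCCCNCC1CCSCC1)[C@H]1CCCc3cccnc31)C2`: compound 1 gives 69.6 nM.
Compound 2, `c1ccc2c(c1)CN[C@@H](CN(CCCCNC1CCCCC1)[C@H]1CCCc3cccnc31)C2`: compound 2 gives 75.2 nM.
Compound 3, `c1ccc2c(c1)CN[C@@H](CN(CCCCNC1CCOCC1)[C@H]1CCCc3cccnc31)C2`: compound 3 gives 29.4 nM.

Compound 3 stands at the lowest number of the three. The step of a 2.4-fold lower number from compound 1 to compound 3 (0.37 log units; beyond the scatter) and the step of a 2.6-fold lower number from compound 2 to compound 3 (0.41 log units; beyond the scatter) are both beyond the scatter, whereas the step of a 1.1-fold higher number from compound 1 to compound 2 (0.03 log units; within the scatter) is within it, so among these three only the oxan-4-yl compound separates itself.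

Compound 4, `CC(C)(N)CCCN(C[C@H]1Cc2ccccc2CN1)[C@H]1CCCc2cccnc21`, is still to be measured in this assay. The change from compound 3 is 1-amino-1-methylethyl in place of ((oxan-4-yl)amino)methyl on a saturated chain carbon, three bonds along the chain from an amine nitrogen. Among the compounds with values here, none of the measured steps bears directly on it: each of the three measured steps exchanges one ring for another on the terminal amine nitrogen and keeps the chain intact, while this change removes the ring altogether and shortens the chain by the counted atoms. Within the data shown here, the measured steps show only that exchanging rings at that position shifts the number modestly; the loss of the ring and of chain length is untested here. A higher number in this assay is therefore expected for compound 4, of uncertain size, with a wide range. The expected step is a 5.1-fold higher number from compound 3 to compound 4 (0.71 log units; beyond the scatter). Compound 4 is estimated at 150 nM, between 40 nM and 600 nM.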

Compound 4, half-maximal inhibitory concentration: 24.6 nM
For compound 4 the middle estimate is 6.1-fold (0.79 log units) above the measured one, and the stated range ends above it.
By their numbers in this assay, from the lowest: compounds 4 and 3 (each within the scatter of the next); then compounds 1 and 2 (each within the scatter of the next).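

Replacing ((oxan-4-yl)amino)methyl with 1-amino-1-methylethyl on a saturated chain carbon, three bonds along the chain from an amine nitrogen, gives a 1.2-fold lower number from compound 3 to compound 4 (0.08 log units; within the scatter) in this assay and shows that the oxan-4-yl ring can be lost here with no change that stands out from the scatter. The earlier compounds shown here varied only the ring-bearing group, whereas the ring-free group also separates from the two other ring-bearing groups, with a 3.1-fold lower number from compound 2 to compound 4 (0.49 log units; beyond the scatter) and with a 2.8-fold lower number from compound 1 to compound 4 (0.45 log units; beyond the scatter) in the same assay; a ring at this position is therefore not required for the lowest numbers in this set, and compound 1 and compound 2 show that carrying a ring does not secure them. Nothing measured among these compounds accounts for this result.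

Going by these compounds, it remains open whether the two methyl groups of 1-amino-1-methylethyl contribute, which a plain aminomethyl or a 1-aminoethyl group at the same carbon would test. Also open, on these data alone, is how far the chain tolerates other ends, such as a longer chain carrying the same primary amine, a hydroxyl in place of that amine, or a carboxylic acid.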